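From piperidin-4-yl to pyrrolidin-3-yl on a carbonyl carbon

The source may report more compounds than this note shows. Statements on the series, on what has been measured and on what is new or still open speak of the compounds shown alone.

Measured so far in an in vitro ADME assay on microsomes from liver (Homo sapiens) for metabolic stability, tested at 1 uM; a lower number here means that the compound disappears faster, a higher number that the compound lasts longer:
Compound 1 `O=C(c1ccc(Cl)nc1)N1CCC(NS(=O)(=O)c2cc(S(=O)(=O)c3ccccc3)ccc2C(F)(F)F)CC1`: > 0.5 h
Compound 2 `O=C(C1CCNCC1)N1CCC(NS(=O)(=O)c2cc(S(=O)(=O)c3ccccc3)ccc2C(F)(F)F)CC1`: > 0.5 h

Compound 2 stands at > 0.5 h, and this is a limit, not a number. Compound 1 gives > 0.5 h, which is also a limit. The record so far is therefore (the limit of > 0.5 h in this assay, at which 2 of the 2 values shown sit).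

Compound 3 `O=C([C@H]1CCNC1)N1CCC(NS(=O)(=O)c2cc(S(=O)(=O)c3ccccc3)ccc2C(F)(F)F)CC1` is the next compound to be followed from compound 2. The change is pyrrolidin-3-yl in place of piperidin-4-yl on a carbonyl carbon. In words, it is pyrrolidin-3-yl in place of piperidin-4-yl on a carbonyl carbon, and the entering group brings one defined stereocentre.

Within the data shown here, only one measured step falls at this place, a step that the two limits leave unreadable from compound 1 to compound 2. It offers no size to carry over, so no step beyond the scatter is expected in this assay, and no direction can be named. The estimated step is a step that the limit leaves unreadable from compound 2 to compound 3. The half-life of compound 3 is expected to be 0.7 h, with an estimated range from 0.4 h to 1.5 h. The read-out may well turn out to be only a limit again.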

Compound 3, half-life: > 0.5 h
Compound 3: no number, only a limit (the forecaster's own chance of this, stated with the estimate: 75%); the middle value is on the limit's open side.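

In this assay compound 3 gives > 0.5 h, which is a limit and not a number. The steps to compound 3 from compound 1 and from compound 2 cannot be read, as the record holds only limits: the limit of > 0.5 h in this assay, at which 3 of the 3 values shown sit.

The compounds shown leave open the actual half-life of each compound, and whether pyrrolidin-3-yl, piperidin-4-yl or 6-chloropyridin-3-yl on the carbonyl carbon makes any difference to it.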